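Solubility notes: two measured compounds, one proposed

The source may report more compounds than this note shows. Statements on the series, on what has been measured and on what is new or still open speak of the compounds shown alone.

Measured so far:
- compound 1 `N#CCC(=O)Nc1cc(-c2ccc(Cl)c(Cl)c2)cs1`, 12000 nM
- compound 2 `O=C1CCCC(C(=O)NC2=NN(c3ccc(Cl)c(Cl)c3)CC2)N1`, 416000 nM

In a physicochemical assay for solubility, measured as kinetic solubility, with a stated time of 1 h, at pH 7.4 (on this read-out lower numbers stand for lower solubility and higher numbers for higher solubility), compound 2 gives 416000 nM, the higher of the two numbers recorded; compound 1 gives 12000 nM, and that gap lies beyond the scatter. Among the measured compounds shown here, no pair of measured compounds differs in only one place, so no measured single step is available.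

Compound 3 `O=C(NC1=NN(c2ccc(Cl)c(Cl)c2)CC1)c1ccncc1F` is to be measured in this assay. It differs from compound 2 as follows: 3-fluoropyridin-4-yl in place of 6-oxopiperidin-2-yl on a carbonyl carbon.

For the measured compounds named here, with no measured step to lean on, the expectation for compound 3 rests only on the value of compound 2, 416000 nM, and on the change itself. The step from compound 2 to compound 3 is expected to run downward and to lie beyond the scatter, roughly a 6.9-fold lower number from compound 2 to compound 3 (0.84 log units; beyond the scatter). Compound 3 is therefore estimated at 60000 nM, with a range from 15000 nM to 200000 nM.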

Compound 3, solubility: 36000 nM
Compound 3: the middle estimate sits 1.7-fold (0.22 log units) above what was measured; low and high end bracket the measured number.
By their numbers in this assay, from the lowest: compound 1; then compound 3; then compound 2.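

Working notes on the series: in this assay the group on a carbonyl carbon whose other neighbour is amide-type nitrogen proves to matter, since 3-fluoropyridin-4-yl in place of 6-oxopiperidin-2-yl gives a 12-fold lower number from compound 2 to compound 3 (1.06 log units; beyond the scatter). The heavy-atom count stays the same across this change, while a six-membered non-aromatic ring with a hydrogen-bond donor gives way to a six-membered aromatic ring without one, so the step is not a matter of heavy-atom count. Nothing shown here accounts for the step.

Which of the differences between the two groups carries the step remains open, as this single change alters the ring, the donor and the fluorine at once. Also open, as far as these compounds go, is how a pyridin-4-yl without the fluorine, or a piperidine ring bearing an amine, would read on the same carbonyl carbon.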